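The compounds below may be only part of what the source reports. "The series", "measured", "known", "first", "only" and "open" are said of these compounds alone.

Compound 1 `CN(C)C12CC(c3ccccc3)C(CN(C(=O)CCN3CCCCC3)C1)C(c1ccccc1)C2` and compound 2 `CCN(CC)CCC(=O)N1CC2C(c3ccccc3)CC(N(C)C)(CC2c2ccccc2)C1` share one core and differ by diethylamino in place of piperidin-1-yl on a saturated chain carbon, two bonds along the chain from a carbonyl carbon. In an ADME assay on L6 cells (Rattus norvegicus) for cytotoxicity, read by resazurin assay, with a stated time of 72 h (on this read-out higher numbers stand for weaker inhibition and lower numbers for stronger inhibition), compound 1 gives 12400 nM, and compound 2 gives 15400 nM, so that a 1.2-fold higher number from compound 1 to compound 2 (0.09 log units; within the scatter). Compound 3 `CN(C)C12CC(c3ccccc3)C(CN(CCCN3CCCCC3)C1)C(c1ccccc1)C2` differs from compound 1 by 3-(piperidin-1-yl)propyl in place of (2-(piperidin-1-yl)ethyl)carbonyl on an amine nitrogen in a ring. In this assay compound 3 gives 1750 nM; here a 7.1-fold lower number from compound 1 to compound 3 (0.85 log units; beyond the scatter), and an 8.8-fold lower number from compound 2 to compound 3 (0.94 log units; beyond the scatter). Compound 4 `CCN(CC)CCCN1CC2C(c3ccccc3)CC(N(C)C)(CC2c2ccccc2)C1` is not yet measured. It differs from compound 3 by diethylamino in place of piperidin-1-yl on a saturated chain carbon, three bonds along the chain from an amine nitrogen in a ring. This is the same kind of change as that between compound 1 and compound 2, though the place is not the same: two bonds along the chain from a carbonyl carbon in the earlier pair, three bonds along the chain from an amine nitrogen in a ring here. Because the matching step was a 1.2-fold higher number from compound 1 to compound 2 (0.09 log units; within the scatter), compound 4 is expected to show a 1.2-fold higher number from compound 3 to compound 4 (0.08 log units; within the scatter). The estimate for compound 4 in this assay is 2100 nM, with a range from 1000 nM to 4500 nM.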

Compound 4, half-maximal inhibitory concentration: 3270 nM
Compound 4: middle estimate off by 1.6-fold (0.19 log units), on the low side; the range from low to high includes it.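

Swapping piperidin-1-yl for diethylamino gives a 1.9-fold higher number from compound 3 to compound 4 (0.27 log units; within the scatter), and in this assay this step agrees with the one seen on the other core: the same change on two cores in this assay, a 1.2-fold higher number (0.09 log units; within the scatter) from compound 1 to compound 2 and a 1.9-fold higher number (0.27 log units; within the scatter) from compound 3 to compound 4, 1.5-fold (0.18 log units) apart, within the scatter of two such steps. The larger steps stay beyond the scatter and come with the change of the chain on the ring nitrogen, a 4.7-fold lower number from compound 2 to compound 4 (0.67 log units; beyond the scatter) and a 3.8-fold lower number from compound 1 to compound 4 (0.58 log units; beyond the scatter). Within the data shown here, this shows only that a change with no step beyond the scatter stayed that way in two pairs; it does not show that a larger effect would carry over, or that the agreement holds on any further core.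

The compounds shown leave open whether morpholin-4-yl or dimethylamino would fit the same picture. They also leave open what a chain longer than 3-(diethylamino)propyl would do.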